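Methoxy on the benzyl ring of a thiol quinazoline

This account rests on a few compounds, and the source may have more. Where it says the series, first, only, none or still open, it means among the compounds named here.

Measured so far in an ADME assay on BEAS-2B cells (Homo sapiens) for cytotoxicity, read by MTT assay, with a stated time of 72 h; on this read-out lower numbers stand for stronger inhibition of growth and higher numbers for weaker inhibition of growth:
compound 1 `COc1ccc(CNc2nc([SeH])nc3ccccc23)cc1` gives 37400 nM
compound 2 `Sc1nc(NCc2ccccc2)c2ccccc2n1` gives 66300 nM
compound 3 `CSc1nc(NCc2ccccc2)c2ccccc2n1` gives 38900 nM

Compound 2 gives the highest of the three numbers in this assay, but its gaps to the other two are small: the step from compound 2 to compound 3 is a 1.7-fold lower number from compound 2 to compound 3 (0.23 log units; within the scatter), and compound 1 differs from compound 2 in two places, so only the two values themselves can be compared, and they sit within the scatter of each other.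

The next compound, compound 4 `COc1ccc(CNc2nc(S)nc3ccccc23)cc1`, differs from compound 2 by methoxy in place of hydrogen on an aromatic carbon. Within the data shown here, no measured step covers this change on its own: the step from compound 2 to compound 3 concerns the sulfur substituent, and compound 1 carries both the methoxy group and a different substituent on the core. Nothing measured here points to a change in this assay beyond the scatter for a methoxy group on the benzyl ring.

Compound 4 is therefore expected to give a number close to that of compound 2, with the estimated step from compound 2 to compound 4 being a 1.2-fold lower number from compound 2 to compound 4 (0.08 log units; within the scatter). The estimate for compound 4 in this assay is 55000 nM, with a range from 25000 nM to 120000 nM.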

Compound 4, concentration for 50% growth inhibition: 6130 nM
Compound 4: middle estimate off by 9.0-fold (0.95 log units), on the high side, outside the stated range (below it).
By their numbers in this assay, from the lowest: compound 4; then compounds 1, 3 and 2 (each within the scatter of the next).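

Working notes on the series: in this assay, methoxy in place of hydrogen on an aromatic carbon, para to a large group, moves the number well beyond the scatter, an 11-fold lower number from compound 2 to compound 4 (1.03 log units; beyond the scatter). Among these compounds, this position therefore responds to substitution, whereas the one step available from the earlier compounds, on the sulfur, stayed within the scatter. With the methoxy group kept, the atom on the core matters as well, a 6.1-fold lower number from compound 1 to compound 4 (0.79 log units; beyond the scatter), so among the compounds shown only methoxy paired with sulfur reaches a number this low, and nothing at hand offers a reason for either step.

As far as these compounds go, it remains open whether the step belongs to methoxy itself or to any substituent at this place, which a fluorine, a hydroxyl or a longer ethoxy chain on the same aromatic carbon would help to separate. Also open, from the compounds shown here alone, is whether methoxy gives a step of this size when the sulfur carries a methyl group, as it does in compound 3, and whether an amine on the same carbon would behave alike.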